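Solubility notes on the aryl-substituted core series

The compounds below may be only part of what the source reports. "The series", "measured", "known", "first", "only" and "open" are said of these compounds alone.

Compound 1 `CCC(CC)c1ccc2c(NCCCNCc3cc(F)ccc3OC)ccnc2c1` and compound 2 `COc1ccc(F)cc1CNCCCNc1ccnc2cc(Cc3ccc(F)cc3)ccc12` share one core and differ only at a single aromatic carbon. In a physicochemical assay for solubility, with a stated time of 18 h, at pH 7.4 (a higher number here means a more soluble compound, a lower number a less soluble compound), compound 1 gives 4200 nM, and in this assay compound 2 gives 4200 nM. For the measured compounds named here, the only step available, no change at the digits printed from compound 1 to compound 2 (within the scatter), shows that replacing pentan-3-yl with 4-fluorobenzyl at that position left solubility level within the scatter. Compound 2 therefore stands level with compound 1 on the numbers shown.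

Compound 3 `COc1ccc(F)cc1CNCCCNc1ccnc2cc(Oc3ccccc3OC)ccc12` is not yet measured. It differs from compound 2 as follows: 2-methoxyphenoxy in place of 4-fluorobenzyl on an aromatic carbon. Going by the values given here, the step from compound 1 to compound 2 bears on it only loosely, since it exchanged one carbon-only group for another at the same place and showed no change; no measured step covers an entering group that carries oxygen. The working expectation is therefore a step in this assay of about a 1.4-fold higher number from compound 2 to compound 3 (0.15 log units; within the scatter), at or slightly above the scatter, with a wider band than usual. Compound 3 is estimated at 6000 nM, within a range from 2500 nM to 15000 nM.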

Compound 3, solubility: 14500 nM
Compound 3: middle estimate off by 2.4-fold (0.38 log units), on the low side; measured number inside the range.
By their numbers in this assay, from the lowest: compounds 1 and 2 (each within the scatter of the next); then compound 3.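

Working notes on the position: at this aromatic carbon, in this assay, 2-methoxyphenoxy in place of 4-fluorobenzyl gives a 3.5-fold higher number from compound 2 to compound 3 (0.54 log units; beyond the scatter) and is the first exchange in the series to lie beyond the scatter. The same group in place of pentan-3-yl gives a 3.5-fold higher number from compound 1 to compound 3 (0.54 log units; beyond the scatter) so the read-out at this position, flat for the exchange between pentan-3-yl and 4-fluorobenzyl, does move with at least one entering group. The entering group differs from both groups it replaces in carrying oxygen, with 2 hydrogen-bond acceptors counted against 0 for 4-fluorobenzyl, but that is a difference in structure that coincides with the step, and nothing available bears on the reason for the step.

Compound 3 changes several things at once relative to compound 2, with the ring now attached through oxygen, a methoxy group present and the fluorine gone, so the part of 2-methoxyphenoxy that goes with the step cannot be separated. Going by these compounds, whether unsubstituted phenoxy, or a group of another kind such as morpholine or a carboxylic acid at the same aromatic carbon, would give a step of similar size remains open.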